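Tert-butoxy in place of ethoxy in the series

The source may hold more compounds than are shown below. What is called first, only, known or untested is meant among the compounds shown, and "the series" means these compounds.

Compound 1 `CCOC(=O)C(=O)Nc1cccccc1=O` gives 84% in a functional assay on the whole organism (strain Sprague-Dawley CD) for inhibition, with Rattus norvegicus as the target, read by paw edema, at a dose of 30 mg/kg by the intraperitoneal route (on this read-out lower numbers stand for a weaker effect and higher numbers for a stronger effect at the one dose given), and stands highest of the three numbers. Compound 3 `CCOC(=O)C(=O)Nc1ccc(Cl)ccc1=O` gives 27% in this assay, a step of a number 57 percentage points lower from compound 1 to compound 3 (beyond the scatter). Compound 2 `CCOC(=O)C(=O)Nc1c(Oc2ccccc2)ccccc1=O` gives 0% in this assay, a step of a number 84 percentage points lower from compound 1 to compound 2 (beyond the scatter). Both measured steps replace a hydrogen on an aromatic carbon of the shared core, and both lower the read-out beyond the scatter.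

Compound 4 `CC(C)(C)OC(=O)C(=O)Nc1cccccc1=O` differs from compound 1 by tert-butyl in place of ethyl on an oxygen next to a carbonyl group, which cut one bond further out reads ethoxy to tert-butoxy, with the core left untouched. Within the data shown here, neither measured step touches the oxygen next to the carbonyl group; the only changes with numbers sit on aromatic carbons, so no step bears directly on this change, and the series gives no sign of how that part tolerates alteration. The expectation therefore rests on compound 1 alone, with a wide range: compound 4 is expected to give about 70% in this assay, between 35% and 90%. The step from compound 1 is thus expected to be a number 14 percentage points lower from compound 1 to compound 4 (beyond the scatter), plausibly within the scatter.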

Compound 4, a percentage reported as inhibition, in the whole organism at one dose (the size of the read-out at that dose, not a potency): 79%
Compound 4: middle estimate off by 9 percentage points, on the low side; low and high end bracket the measured number.
By their numbers in this assay, from the lowest: compound 2; then compound 3; then compounds 4 and 1 (each within the scatter of the next).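

Among these compounds, the step of a number 5 percentage points lower from compound 1 to compound 4 (within the scatter) is the first with a number at the oxygen next to a carbonyl group, and it places compound 1 and compound 4 within the scatter of each other in this assay. Both replacements on aromatic carbons of the shared core lowered the read-out beyond the scatter, whereas tert-butyl in place of ethyl at this oxygen does not, so this one change is tolerated at this position. No measurement in hand gives a reason for this tolerance.

The compounds shown leave open whether the tolerance extends beyond simple alkyl groups, for instance to a carboxylic acid or to an amine in place of ethoxy. They also leave open whether tert-butoxy behaves the same way on the chloro core of compound 3.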